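A few compounds are considered here, and "the series" means these few. Any claim that something is new, unique, unknown or untested is made for them only; others in the source may bear on it.

Measured so far in a physicochemical assay for solubility; a lower number here means a less soluble compound, a higher number a more soluble compound:
Compound 1 `Nc1ccccc1NC(=O)c1ccc(CNC2=NC(c3ccc(F)cc3)CO2)cc1`: 147 ug/mL
Compound 2 `Nc1ccccc1NC(=O)c1ccc(CNC2=NC(c3cccc(F)c3)CO2)cc1`: >= 131 ug/mL

Compound 2 sits at the limit of >= 131 ug/mL in this assay, at which 1 of the 2 values shown sits, which is a limit of the assay and not a number. The next compound, compound 3 `Nc1ccccc1NC(=O)c1ccc(CNC2=NC(c3ccc(C(F)(F)F)cc3)CO2)cc1`, keeps the shared core and changes one group: 4-(trifluoromethyl)phenyl in place of 3-fluorophenyl on a saturated ring carbon. In words, 4-(trifluoromethyl)phenyl takes the place of 3-fluorophenyl on a saturated ring carbon of the five-membered non-aromatic ring. Both groups carry no net charge and hold one six-membered aromatic ring of carbon only.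

Within the data shown here, one measured step bears on this change: a step that the limit leaves unreadable from compound 1 to compound 2. It concerns the same saturated ring carbon, but its size cannot be read, so it offers no size to carry over. Among the measured compounds shown here, that leaves compound 1 at 147 ug/mL as the only true number to lean on. A modest fall in this assay is therefore expected, held with caution, and a change within the scatter would not be surprising. The expected step is an at least 1.4-fold lower number from compound 2 to compound 3 (0.16 log units; that floor lies within the scatter). For compound 3 the estimated value is 90 ug/mL, with an expected range of 30 ug/mL to 170 ug/mL.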

Compound 3, solubility: 8 ug/mL
For compound 3 the middle estimate is 11-fold (1.05 log units) above the measured one, outside the stated range (below it).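

In this assay, the group on this aromatic ring turns out to matter a great deal, which the earlier pair could not show, as the step between compound 1 and compound 2 cannot be read: going from 4-fluorophenyl to 4-(trifluoromethyl)phenyl, with trifluoromethyl in place of fluoro on an aromatic carbon, gives an 18-fold lower number from compound 1 to compound 3 (1.26 log units; beyond the scatter). Compound 2 carries a limit of the assay and not a number: the limit of >= 131 ug/mL in this assay, at which 1 of the 3 values shown sits. Even measured from that limit, 4-(trifluoromethyl)phenyl in place of 3-fluorophenyl gives an at least 16-fold lower number from compound 2 to compound 3 (1.21 log units; beyond the scatter), so both readable steps into compound 3 are large and point the same way.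

Going by these compounds, how a 3-(trifluoromethyl)phenyl group, or a phenyl ring carrying a methoxy group or an amine, would read on this saturated ring carbon remains open, and with it whether the large fall belongs to trifluoromethyl alone. On these data alone, compound 2 has no true number either, so how far the 3-fluorophenyl and 4-fluorophenyl compounds stand apart also stays unknown.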